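This account rests on a few compounds, and the source may have more. Where it says the series, first, only, none or still open, it means among the compounds named here.

Measured compounds:
- compound 1, `Cc1ccnc(/C(N)=N/NC(=S)N2CCOCC2)c1`: 90.6%
- compound 2, `N/C(=N\NC(=S)N1CCCCC1)c1ccccn1`: 88.5%

In a functional assay on A-375 cells (Homo sapiens) for cytotoxicity, read by MTT assay, with a stated time of 72 h, tested at 100 uM (on this read-out higher numbers stand for more inhibition of growth at the one concentration tested and lower numbers for less inhibition of growth), compound 1 gives 90.6% and compound 2 gives 88.5%. Compound 2 stands as the lower of the two numbers, but its nearest neighbour is compound 1, whose value lies higher by an amount within the scatter, so the two cannot be told apart on this read-out. Compound 3, `Cc1ccnc(/C(N)=N/NC(=S)N2CCCCC2)c1`, is the not yet measured member of the set; it differs from compound 2 by methyl in place of hydrogen on an aromatic carbon, on a six-membered aromatic ring with one nitrogen, meta to a large group and opposite the ring nitrogen. For the measured compounds named here, no step between measured compounds that share exactly this change is known here. Since both measured compounds already sit near the top of the scale in this assay, the step from compound 2 to compound 3 is expected to be small and no larger than the scatter, in either direction. Compound 3 is accordingly estimated at 89%, with a range from 80% to 96%, corresponding to an expected step of a number 0.5 percentage points higher from compound 2 to compound 3 (within the scatter).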

Compound 3, percent growth inhibition at one concentration: 85.6%
Beside the measured number, compound 3's estimate is 3.4 percentage points above it; measured number inside the range.
By their numbers in this assay, from the lowest: compounds 3, 2 and 1 (each within the scatter of the next).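

In this assay, for the compounds shown here, methyl in place of hydrogen on an aromatic carbon, meta to a large group and opposite the ring nitrogen, gives a number 2.9 percentage points lower from compound 2 to compound 3 (within the scatter) and so leaves no step at this position that can be told from the scatter. Piperidin-1-yl in place of morpholin-4-yl on a thiocarbonyl carbon gives a number 5 percentage points lower from compound 1 to compound 3 (within the scatter) and likewise stays within the scatter in the presence of the methyl. Nothing available bears on why these steps are this small.

From the compounds shown here alone, all three compounds stand close together at the one concentration tested, so whether any group at this position can move the number beyond the scatter stays open. Whether an amine, a carboxylic acid or a longer chain such as propyl in place of the methyl would do so is also unanswered.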